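From isobutyl to trifluoromethyl: estimating an unmeasured permeability

This account rests on a few compounds, and the source may have more. Where it says the series, first, only, none or still open, it means among the compounds named here.

Compound 1 `CC(C)COc1ncc(-c2cn(C)c3cc(C(=O)NS(C)(=O)=O)ccc23)cc1Cl` gives 216 nm/s
Compound 2 `CC(C)Cc1ccc(-c2cn(C)c3cc(C(=O)NS(C)(=O)=O)ccc23)cc1` gives "not determined" (no result reported)
Compound 3 `Cn1nc(-c2ccc(C(F)(F)F)cc2)c2cc(F)c(C(=O)NS(=O)(=O)C3CC3)cc21` gives 102 nm/s

Within the data shown here, these entries come from an ADME assay for permeability, using PAMPA, at pH 7.4 (on this read-out higher numbers stand for higher permeability and lower numbers for lower permeability), and only two of them are numbers. Compound 2 therefore stands nowhere on the scale, and its entry remains "not determined" (no result reported) with no single figure to serve as a starting point. The compound still to be measured is compound 4 `Cn1cc(-c2ccc(C(F)(F)F)cc2)c2ccc(C(=O)NS(C)(=O)=O)cc21` and it comes from a single structural change, trifluoromethyl in place of isobutyl on an aromatic carbon (trifluoromethyl in place of isobutyl on an aromatic carbon, para to a large group).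

Among the measured compounds shown here, no measured pair in this small set shows what such a change does. Without a number for compound 2, the size of the step cannot be worked out, so no step beyond the usual scatter is expected in either direction. For the measured compounds named here, the expectation leans instead on the two measured compounds, compound 1 at 216 nm/s and compound 3 at 102 nm/s in this assay as the only guide. Compound 3 also carries a trifluoromethyl group, though it differs from compound 4 in other places too. Compound 4 is estimated at 140 nm/s with an expected range of 50 nm/s to 350 nm/s on this limited evidence.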

Compound 4, apparent permeability: 171 nm/s
Compound 4: middle estimate off by 1.2-fold (0.09 log units), on the low side; low and high end bracket the measured number.
By their numbers in this assay, from the lowest: compounds 3, 4 and 1 (each within the scatter of the next, the first and the last beyond it).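

In this assay, among these compounds, compound 4 gives 171 nm/s while compound 2 has no single number, so no step between compound 2 and compound 4 can be read. The compounds shown leave open what trifluoromethyl in place of isobutyl does on this read-out. No evidence shown here bears on the value of compound 4.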